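Acid ceramidase series: acetylpiperidine replacing isobutylpiperazine

A few compounds are considered here, and "the series" means these few. Any claim that something is new, unique, unknown or untested is made for them only; others in the source may bear on it.

Measured so far in an assay on HEK293 cells for inhibition of acid ceramidase (Homo sapiens), read by fluorescence, with stated times of 10 min and 3 h; on this read-out lower numbers stand for stronger inhibition and higher numbers for weaker inhibition:
compound 1, `CC(C)CNC(=O)n1c(=O)oc2cc(C3CCN(C)CC3)ccc21`: 166 nM
compound 2, `CC(C)CN1CCN(c2ccc3c(c2)oc(=O)n3C(=O)NCCCCc2ccccc2)CC1`: 127 nM

Two compounds share the core and differ in both the urea substituent and the group on the aromatic carbon. In this assay, among the measured compounds shown here, compound 2 gives 127 nM and compound 1 gives 166 nM; the gap between these two numbers lies within the usual scatter, so neither compound is set apart from the other on this assay, and no step between them can be read.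

Compound 3, `CC(=O)N1CCC(c2ccc3c(c2)oc(=O)n3C(=O)NCCCCc2ccccc2)CC1`, keeps the phenylbutyl urea of compound 2 and changes only the aromatic substituent: 1-acetylpiperidin-4-yl in place of 4-isobutylpiperazin-1-yl on an aromatic carbon. For the measured compounds named here, the basic ring nitrogen of the group that leaves has no counterpart in the group that enters; the entering group carries an acetyl instead. Going by the values given here, no measured pair shows the effect of this kind of change, so the expectation rests on the tolerance seen across compounds 1 and 2, where two different saturated rings give numbers within the scatter of each other.

A modest loss, possibly none beyond the scatter, is expected from compound 2 to compound 3, a 1.7-fold higher number from compound 2 to compound 3 (0.24 log units; within the scatter). Compound 3 is estimated at 220 nM in this assay, with a likely range from 60 nM to 800 nM.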

Compound 3, half-maximal inhibitory concentration: 64 nM
Estimate against measurement, compound 3: 3.4-fold (0.54 log units) above; the measured number falls inside the stated range.
By their numbers in this assay, from the lowest: compounds 3, 2 and 1 (each within the scatter of the next, the first and the last beyond it).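

In this assay the exchange of 4-isobutylpiperazin-1-yl for 1-acetylpiperidin-4-yl on this aromatic carbon gives a 2.0-fold lower number from compound 2 to compound 3 (0.30 log units; within the scatter) and so cannot be told apart from no effect, with the phenylbutyl urea held constant. This pair isolates the position, which compounds 1 and 2 could not do because they differ in two places; here a six-membered non-aromatic ring with 1 hetero atom and an acetyl on that ring's nitrogen reads alike with a ring carrying 2 hetero atoms and an isobutyl group. No measurement shown bears on why the two groups read alike.

The compounds shown leave open how far this tolerance extends: whether the ring itself is needed could be tested with an open-chain amine or a plain phenyl ring on the same aromatic carbon, and a benzoyl or a longer acyl chain in place of the acetyl would test the size accepted on the ring nitrogen. Going by these compounds, it also remains open how the 1-methylpiperidine ring of compound 1 reads when paired with the phenylbutyl urea, a match that would connect compound 1 to the pair through single-place steps.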